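The compounds below may be only part of what the source reports. "The series", "measured", "known", "first", "only" and "open" are said of these compounds alone.

Compound 3, `CC1=CC[C@H]2[C@H](CC[C@]2(C)O)C(C)(C)[C@@H]1CC[C@H]1[C@]2(C)CC[C@H](OC(=O)c3ccc(C(F)(F)F)cc3)C(C)(C)O[C@H]2CC[C@@]1(C)O`, is the starting point of this step. In a functional assay on MCF7 cells (Homo sapiens) for antiproliferative activity, read by MTT assay, with a stated time of 72 h (a higher number here means a weaker inhibitor, a lower number a stronger inhibitor), compound 3 gives 23400 nM. Compound 1, `CC(=O)O[C@H]1CC[C@]2(C)[C@H](CC[C@@](C)(O)[C@H]2CC[C@@H]2C(C)=CC[C@@H]3C(C)=CC[C@@H]3C2(C)C)OC1(C)C`, carries an acetyl on the same oxygen and gives 43500 nM in this assay, so compound 3 holds the lower of the two numbers, though the gap to compound 1 lies within the scatter. Compound 2, `CC1=CC[C@H]2[C@@H]1CC=C(C)[C@@H](CC[C@H]1[C@]3(C)CC[C@H](OCc4ccccc4)C(C)(C)O[C@H]3CC[C@@]1(C)O)C2(C)C`, gives only a limit of this assay, > 50000 nM. Among the measured compounds shown here, the one step measured at that oxygen, an at least 1.1-fold higher number from compound 1 to compound 2 (0.06 log units; that floor lies within the scatter), rests on the limit of > 50000 nM in this assay, at which 1 of the 3 values shown sits, and says little about the size of a change there.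

Compound 4, `CC1=CC[C@H]2[C@H](CC[C@]2(C)O)C(C)(C)[C@@H]1CC[C@H]1[C@]2(C)CC[C@H](OC(=O)c3ccco3)C(C)(C)O[C@H]2CC[C@@]1(C)O`, differs from compound 3 by furan-2-yl in place of 4-(trifluoromethyl)phenyl on a carbonyl carbon. For the measured compounds named here, no measured step swaps one aromatic ring for another on this carbonyl carbon, so nothing among the measured compounds points to a direction. He therefore expects no step beyond the scatter, a 1.3-fold higher number from compound 3 to compound 4 (0.11 log units; within the scatter), and estimates that compound 4 will give 30000 nM in this assay, with a range from 12000 nM to 70000 nM.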

Compound 4, half-maximal inhibitory concentration: 25700 nM
The estimate for compound 4 lay 1.2-fold (0.07 log units) above the measured number, and the stated range covers the measured number.
By their numbers in this assay, from the lowest: compounds 3, 4 and 1 (each within the scatter of the next). At a limit, above all of these: compound 2.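

On this carbonyl carbon, a five-membered aromatic ring with 1 hetero atom takes the place of a six-membered aromatic ring of carbon only, and the step stays small: a 1.1-fold higher number from compound 3 to compound 4 (0.04 log units; within the scatter) in this assay. Among the compounds shown here, this is the first measured step between two aromatic rings at this place, and it shows that the 4-(trifluoromethyl)phenyl group, with its fluorine atoms, can give way to furan-2-yl without a change beyond the scatter. Nothing measured among these compounds offers a reason for so small a step.

For the compounds shown here, no step that can be read at this oxygen lies beyond the scatter, so it remains open whether the group carried there matters at all in this assay. Whether an amine, a carboxylic acid or a longer chain on this carbonyl carbon would give a larger step also stays unanswered.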